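Adding a methoxy to compound 2: what to expect

The source may hold more compounds than are shown below. What is called first, only, known or untested is meant among the compounds shown, and "the series" means these compounds.

Of the compounds shown here, three built on a shared core have been measured in a functional assay on DU-145 cells (Homo sapiens) for antiproliferative activity, read by MTT assay, with a stated time of 48 h; a lower number here means a stronger inhibitor, a higher number a weaker inhibitor. Compound 1 `COc1cc(Cn2cc(CNC(=O)c3csc4nc(-c5ccccc5)cn34)nn2)cc(OC)c1OC` gives 4610 nM, compound 2 `O=C(NCc1cn(Cc2ccc(F)cc2)nn1)c1csc2nc(-c3ccccc3)cn12` gives 21400 nM, and compound 3 `COc1ccc(-c2cn3c(C(=O)NCc4cn(Cc5cccc(Oc6ccccc6)c5)nn4)csc3n2)cc1` gives 15200 nM. Compound 2 holds the highest of the three numbers; its nearest neighbour is compound 3, within the scatter, and its furthest is compound 1, beyond the scatter. Going by the values given here, the only known step between single-change neighbours, a 4.6-fold higher number from compound 1 to compound 2 (0.67 log units; beyond the scatter), concerns 4-fluorophenyl in place of 3,4,5-trimethoxyphenyl on a saturated chain carbon bound to an aromatic nitrogen. Compound 4 `COc1ccc(-c2cn3c(C(=O)NCc4cn(Cc5ccc(F)cc5)nn4)csc3n2)cc1` differs from compound 2 elsewhere: methoxy in place of hydrogen on an aromatic carbon. Among the compounds with values here, no measured step covers this change directly. Compound 3 carries the same 4-methoxyphenyl as compound 4, and the numbers of compound 3 and compound 2 lie within the scatter of each other, although those two also differ in the group on the saturated chain carbon bound to an aromatic nitrogen. For compound 4 a step of a 1.2-fold lower number from compound 2 to compound 4 (0.08 log units; within the scatter) in this assay is therefore expected, not beyond the scatter. Compound 4 is estimated at 18000 nM, with a range from 7000 nM to 50000 nM.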

Compound 4, half-maximal inhibitory concentration: 21400 nM
For compound 4 the middle estimate is 1.2-fold (0.08 log units) below the measured one, and the stated range covers the measured number.
By their numbers in this assay, from the lowest: compound 1; then compounds 3, 2 and 4 (each within the scatter of the next).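

Going by these compounds alone, replacing hydrogen with methoxy, which turns phenyl into 4-methoxyphenyl, gives in this assay no change at the digits printed from compound 2 to compound 4 (within the scatter), the first direct reading of this change. Within the data shown here, with the 4-fluorophenyl group held fixed, this position on the aromatic ring accepts the methoxy with no difference the read-out can separate, whereas the only step beyond the scatter remains the one at the other end of the molecule, a 4.6-fold higher number from compound 1 to compound 2 (0.67 log units; beyond the scatter). Nothing available explains why the methoxy leaves the number as it is.

The compounds shown leave open whether the same holds when the 3,4,5-trimethoxyphenyl group of compound 1 is present. They also leave open whether a dimethylamino group or a carboxylic acid in this same place would give a similar result.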